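A few compounds are considered here, and "the series" means these few. Any claim that something is new, unique, unknown or untested is made for them only; others in the source may bear on it.

Working notes on the series. Compound 1 `Nc1ccccc1NC(=O)c1ccc(CNC2=N[C@@H](Cc3ccccc3)CS2)cc1`, compound 2 `Nc1ccccc1NC(=O)c1ccc(CNC2=NC(=O)C(c3ccccc3)N2)cc1` and compound 3 `Nc1ccccc1NC(=O)c1ccc(CNC2=N[C@@H](c3ccc(O)cc3)CS2)cc1` share one core and differ only in the ring attached through the benzylic amine. In an assay on isolated protein for inhibition of protein deacetylase HDAC6 (Homo sapiens), read by fluorescence, with stated times of 3 h and 60 min (on this read-out lower numbers stand for stronger inhibition and higher numbers for weaker inhibition), compound 1 returns only a limit, > 20000 nM. Compound 2 likewise returns only a limit in this assay, > 20000 nM. For compound 3 the entry in this assay reads "not determined" (no result reported). Compound 2 therefore sits at the limit of > 20000 nM in this assay, at which 2 of the 3 values shown sit, and no number places it relative to the others. Compound 4 `Nc1ccccc1NC(=O)c1ccc(CNC2=NC(=O)C(Cc3c[nH]c4ccccc34)N2)cc1` differs from compound 2 by (1H-indol-3-yl)methyl in place of phenyl on a saturated ring carbon. For the measured compounds named here, no measured step in this assay anchors this change, and no shift beyond the scatter is expected. Compound 4 is estimated at 30000 nM, within 8000 nM to 100000 nM. The expected step is a step that the limit leaves unreadable from compound 2 to compound 4.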

Compound 4, half-maximal inhibitory concentration: > 20000 nM
Compound 4: no number, only a limit; the forecaster's own chance of this, stated with the estimate: 75%; the middle value does not contradict the limit.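

For the compounds shown here, compound 2 and compound 4 both return only limits in this assay, and no step between them can be read. The compounds shown leave open whether (1H-indol-3-yl)methyl in place of phenyl changes inhibition at all.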